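The source may hold more compounds than are shown below. What is called first, only, known or untested is meant among the compounds shown, and "the series" means these compounds.

Measured so far in an in vivo functional assay on the whole organism (brain) for inhibition of Norepinephrine transporter (Rattus norvegicus); a lower number here means that less compound is needed, a higher number that more compound is needed for the effect:
compound 1, `CN(C)C/C=C(/c1ccc(Cl)cc1)c1cccnc1`, gives 38 umol/kg.
compound 2, `CN(C)C/C=C(/c1ccc(I)cc1)c1cccnc1`, gives > 88 umol/kg.

Compound 2 stands only at a limit of this assay: its value is the limit itself, not a number, as the limit of > 88 umol/kg in this assay, at which 1 of the 2 values shown sits, records. For the measured compounds named here, the one measured step, an at least 2.3-fold higher number from compound 1 to compound 2 (0.36 log units; beyond the scatter), replaced chloro with iodo on the aromatic carbon and raised the dose needed.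

Compound 3, `CN(C)C/C=C(/c1ccc(C(F)(F)F)cc1)c1cccnc1`, differs from compound 2 by trifluoromethyl in place of iodo on an aromatic carbon. Going by the values given here, that step bears on the change only in that the iodo which accompanied the rise now leaves again, while a new group of different kind enters; no measured step shows trifluoromethyl at this place. Compound 3 is therefore expected to return toward the range of compound 1 rather than move further, giving an expected at least 1.2-fold lower number from compound 2 to compound 3 (0.09 log units; that floor lies within the scatter). The estimate for compound 3 in this assay is 70 umol/kg, expected to fall between 30 umol/kg and 200 umol/kg.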

Compound 3, dose for half-maximal effect: > 101 umol/kg
Compound 3 gave a limit, no number (the forecaster's own chance of this, stated with the estimate: 40%); at least 1.4-fold (0.15 log units) between middle value and limit.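

The new information is that trifluoromethyl in place of chloro on the aromatic carbon, para to a large group, gives an at least 2.6-fold higher number from compound 1 to compound 3 (0.42 log units; beyond the scatter) in this assay, so the rise in dose is no longer seen with iodo alone. Compound 3 stands at a limit, not a number: the limit of > 101 umol/kg in this assay, at which 1 of the 3 values shown sits. Compound 2 also stands at a limit, so the step between these two compounds cannot be read and the two groups cannot be ordered: the limit of > 88 umol/kg in this assay, at which 1 of the 3 values shown sits.

Going by these compounds, how much compound either one actually needs stays open. Also open, on these data alone, is whether fluoro, methoxy or a nitrile at this place would stay close to compound 1, which gives 38 umol/kg, or would also raise the dose needed.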